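Butylamino addition on a quinone series: transfer to compound 4

This account rests on a few compounds, and the source may have more. Where it says the series, first, only, none or still open, it means among the compounds named here.

Of the compounds shown here, three have been measured in a functional assay on NCI-H460 cells (Homo sapiens) for cytotoxicity, read by MTT assay, with a stated time of 72 h; on this read-out lower numbers stand for stronger inhibition and higher numbers for weaker inhibition. Compound 3 `CC(C)(C)C1=CC(=O)C=CC1=O` gives 72000 nM. Compound 1 `CCCCNC1=CC(=O)C=C(C(C)(C)C)C1=O` gives 13000 nM. Compound 2 `CC1=CCC[C@H]2[C@](C)(CC3=CC(=O)C=CC3=O)[C@@H](C)CC[C@]12C` gives 24000 nM. Within the data shown here, the step of a 5.5-fold lower number from compound 3 to compound 1 (0.74 log units; beyond the scatter) is the only single-point change among the measured compounds; it is described as butylamino in place of hydrogen on a double-bonded ring carbon. Compound 2 and compound 1 lie within the scatter of each other, while compound 2 and compound 3 differ beyond it; the difference between the core of compound 2 and the core of compound 3 is not broken down here.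

Compound 4 `CCCCNC1=CC(=O)C=C(C[C@]2(C)[C@@H](C)CC[C@]3(C)C(C)=CCC[C@@H]23)C1=O` has not yet been measured in this assay. It differs from compound 2 by butylamino in place of hydrogen on a double-bonded ring carbon. This is the same kind of change as that from compound 3 to compound 1, but the surroundings are not identical: in the measured pair the place is two ring bonds from the ring atom that bears a tert-butyl group, whereas in compound 4 it is two ring bonds from the ring atom that bears a large group. The step from compound 2 to compound 4 is expected to be a 4.8-fold lower number from compound 2 to compound 4 (0.68 log units; beyond the scatter), resting on the measured step of a 5.5-fold lower number from compound 3 to compound 1 (0.74 log units; beyond the scatter) applied to compound 2, with allowance for the different group at the neighbouring ring atom. On that basis compound 4 is estimated at 5000 nM, expected to fall between 2000 nM and 15000 nM in this assay.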

Compound 4, half-maximal inhibitory concentration: 6000 nM
Compound 4: the middle estimate sits 1.2-fold (0.08 log units) below what was measured; low and high end bracket the measured number.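

In this assay, butylamino in place of hydrogen on a double-bonded ring carbon gives a 4.0-fold lower number from compound 2 to compound 4 (0.60 log units; beyond the scatter). The change therefore lowers the number on both cores, and the two step sizes cannot be told apart, even though the ring atom two ring bonds from the place bears a tert-butyl group in one pair and a large group in the other: the same change on two cores in this assay, a 5.5-fold lower number (0.74 log units; beyond the scatter) from compound 3 to compound 1 and a 4.0-fold lower number (0.60 log units; beyond the scatter) from compound 2 to compound 4, 1.4-fold (0.14 log units) apart, within the scatter of two such steps

Among these compounds, this agreement rests on only two pairs and a single substituent, so it does not show that the step would hold on a further core or on any read-out other than this assay, and it gives no explanation of why the number falls.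

The compounds shown leave open whether the size of the step depends on the chain itself, for example whether a propylamino or hexylamino chain, a morpholine ring or a plain hydroxyl group in the same place would give a comparable step. From the compounds shown here alone, it also remains open whether the step would persist on a quinone carrying only a methyl group where these two cores carry their tert-butyl and large groups.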